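Dropping the Methyl Group from Compound 2

The compounds below may be only part of what the source reports. "The series", "measured", "known", "first", "only" and "open" are said of these compounds alone.

In an assay on adrenal cortex for inhibition of angiotensinogen (Rattus norvegicus) (on this read-out higher numbers stand for weaker inhibition and lower numbers for stronger inhibition), the three measured compounds stand as follows:

Compound 1 `CCCC1N(Cc2ccc(-c3ccccc3-c3nn[nH]n3)cc2)C(=O)c2ccccc2N1C` gives 540 nM
Compound 2 `CCC1Nc2ccc(C)cc2C(=O)N1Cc1ccc(-c2ccccc2-c2nn[nH]n2)cc1` gives 13000 nM
Compound 3 `CCCCC1Nc2ccc(C(C)C)cc2C(=O)N1Cc1ccc(-c2ccccc2-c2nn[nH]n2)cc1` gives 1100 nM

Compound 2 has the highest number of the three, which on this read-out means the weakest inhibition. Its nearest neighbour is compound 3, whose number is lower by a margin that goes beyond the usual scatter of repeated measurements, and compound 1 lies lower still. Compounds 1 and 3 differ from compound 2 in several places at once, so none of these gaps can be traced to a single change.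

Compound 4 `CCC1Nc2ccccc2C(=O)N1Cc1ccc(-c2ccccc2-c2nn[nH]n2)cc1` is the compound still to be measured. It differs from compound 2 in one place only: hydrogen in place of methyl on an aromatic carbon. The change removes a small group from the shared core and leaves everything else untouched.

Within the data shown here, no single-change step among the measured compounds shows what this kind of change does. Without such a precedent, the expectation for a 1.3-fold lower number from compound 2 to compound 4 (0.11 log units; within the scatter) is a step that stays within the usual scatter, in either direction. On that basis compound 4 is estimated to give 10000 nM in this assay, with a likely range from 3500 nM to 30000 nM.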

Compound 4, half-maximal inhibitory concentration: 45000 nM
The estimate for compound 4 lay 4.5-fold (0.65 log units) below the measured number; the whole stated range lies below it.
By their numbers in this assay, from the lowest: compound 1; then compound 3; then compound 2; then compound 4.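

In this assay the aromatic carbon that carries the methyl group in compound 2 is not a place where the group can be lost at no cost: hydrogen in place of methyl gives a 3.5-fold higher number from compound 2 to compound 4 (0.54 log units; beyond the scatter), and on this read-out a higher number stands for weaker inhibition. Among these compounds, this is the first change in the set that can be read on its own, since the earlier compounds differ from each other in several places at once. It shows that a single carbon, on a ring position meta to a fused ring and para to a fused ring, is enough to move the number by more than repeat measurements would, though nothing shown here explains the shift.

The compounds shown compare only methyl and hydrogen at this aromatic carbon, so it stays open whether an ethyl group, a methoxy group or a chlorine atom there would lower the number further or raise it. Going by these compounds, it also stays open whether removing the methyl group would cost as much on a version of the shared core with a longer chain, such as butyl.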